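Trimming Two Methyls from an Oxetane Ring

The compounds below may be only part of what the source reports. "The series", "measured", "known", "first", "only" and "open" are said of these compounds alone.

Three measured compounds share one core and differ only in the ring carried on a saturated chain carbon bound to a sulfonamide nitrogen. Compound 1 `CC1(C)C[C@@H](CN([C@H](CCC(F)(F)F)C(N)=O)S(=O)(=O)c2ccc(Cl)cc2)O1` carries a 4,4-dimethyloxetan-2-yl ring, and in an ADME assay on MDCKII-LE cells (Canis lupus familiaris) for permeability, read by transwell migration, in the apical to basolateral direction (on this read-out higher numbers stand for higher permeability and lower numbers for lower permeability), compound 1 gives 14.9 10^-6 cm/s, the lowest of the three numbers, although all three lie within the scatter of one another. Compound 2 `NC(=O)[C@@H](CCC(F)(F)F)N(C[C@@H]1COCCO1)S(=O)(=O)c1ccc(Cl)cc1` carries a 1,4-dioxan-2-yl ring, and in this assay compound 2 gives 27.3 10^-6 cm/s. Compound 3 `NC(=O)[C@@H](CCC(F)(F)F)N(C[C@H]1CCCO1)S(=O)(=O)c1ccc(Cl)cc1` carries an oxolan-2-yl ring, and in this assay compound 3 gives 19.1 10^-6 cm/s. The measured steps are a 1.8-fold higher number from compound 1 to compound 2 (0.26 log units; within the scatter), a 1.3-fold higher number from compound 1 to compound 3 (0.11 log units; within the scatter) and a 1.4-fold lower number from compound 2 to compound 3 (0.16 log units; within the scatter), each small. Compound 4 `NC(=O)[C@@H](CCC(F)(F)F)N(C[C@H]1CCO1)S(=O)(=O)c1ccc(Cl)cc1` is not yet measured and differs from compound 1 in one place: oxetan-2-yl in place of 4,4-dimethyloxetan-2-yl on a saturated chain carbon bound to a sulfonamide nitrogen. Because a 1.8-fold higher number from compound 1 to compound 2 (0.26 log units; within the scatter) and a 1.3-fold higher number from compound 1 to compound 3 (0.11 log units; within the scatter) both fall within the scatter, no step beyond the scatter is expected for a 1.0-fold higher number from compound 1 to compound 4 (0.00 log units; within the scatter). Compound 4 is therefore estimated at 15 10^-6 cm/s, with a range from 8 10^-6 cm/s to 30 10^-6 cm/s.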

Compound 4, apparent permeability: 28.7 10^-6 cm/s
Compound 4: middle estimate off by 1.9-fold (0.28 log units), on the low side; the measured number falls inside the stated range.
By their numbers in this assay, from the lowest: compounds 1, 3, 2 and 4 (each within the scatter of the next).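

Taking the methyls off the ring on a saturated chain carbon bound to a sulfonamide nitrogen, which turns 4,4-dimethyloxetan-2-yl into oxetan-2-yl, gives a 1.9-fold higher number from compound 1 to compound 4 (0.28 log units; within the scatter) in this assay. The oxetan-2-yl ring can also be set against the other two rings: the comparison gives a 1.5-fold higher number from compound 3 to compound 4 (0.18 log units; within the scatter) and also a 1.1-fold higher number from compound 2 to compound 4 (0.02 log units; within the scatter). Even with the ring reduced to 4 heavy atoms, all four compounds stay within the scatter of one another, so among these compounds this position shows no clear sensitivity to which of these oxygen-containing rings it carries.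

Nothing shown here offers an explanation for the small differences that remain. Also open, going by these compounds, is whether a group of another kind at this place, such as an amine or a carboxylic acid, would stay within that same scatter.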